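The compounds below may be only part of what the source reports. "The series", "measured", "known", "first", "only" and "open" are said of these compounds alone.

Working notes on the series. The shared core carries an amide to a chloro-nitro aryl piece on one side and a sulfonamide on the other; compound 1 `Cc1cc(NC(=O)c2ccc(Cl)c([N+](=O)[O-])c2)ccc1NS(=O)(=O)C(F)(F)F`, compound 2 `CS(=O)(=O)Nc1ccc(NC(=O)c2ccc(Cl)c([N+](=O)[O-])c2)cc1F` and compound 3 `CCS(=O)(=O)Nc1ccc(NC(=O)c2ccc(Cl)c([N+](=O)[O-])c2)cc1F` have been measured, compound 4 `O=C(Nc1ccc(NS(=O)(=O)C(F)(F)F)c(F)c1)c1ccc(Cl)c([N+](=O)[O-])c1` has not. In an ADME assay on RAW264.7 cells (Mus musculus) for cytotoxicity, read by MTT assay, with a stated time of 48 h (a higher number here means a weaker inhibitor, a lower number a stronger inhibitor), compound 1 gives 89800 nM, compound 2 gives 102000 nM and compound 3 gives 198000 nM. Compound 3 holds the highest number of the three: the nearest is compound 2, within the scatter, the furthest compound 1, beyond it. Going by the values given here, the one recorded single-point step is a 1.9-fold higher number from compound 2 to compound 3 (0.29 log units; within the scatter).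

Compound 4 arises from compound 3 by trifluoromethyl in place of ethyl on a sulfonyl sulfur. Among the compounds with values here, no recorded step exchanges the group on the sulfonyl sulfur in this way, so the bearing is indirect: from compound 2 to compound 3 a change on the same sulfur stayed within the scatter, and compound 1, which also carries a trifluoromethyl on the sulfonyl sulfur but differs from compound 3 in a second place, sits beyond the scatter below compound 3. A modest step down is therefore expected, a 1.8-fold lower number from compound 3 to compound 4 (0.26 log units; within the scatter) being the estimated size. For compound 4 in this assay the estimate is 110000 nM, with a range from 45000 nM to 270000 nM.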

Compound 4, half-maximal inhibitory concentration: 188000 nM
The estimate for compound 4 lay 1.7-fold (0.23 log units) below the measured number; measured number inside the range.
By their numbers in this assay, from the lowest: compounds 1, 2, 4 and 3 (each within the scatter of the next, the first and the last beyond it).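

In this assay, the exchange of ethyl for trifluoromethyl on the sulfonyl sulfur gives a 1.1-fold lower number from compound 3 to compound 4 (0.02 log units; within the scatter) and the exchange of methyl for trifluoromethyl gives a 1.8-fold higher number from compound 2 to compound 4 (0.27 log units; within the scatter), so with fluoro held on the aromatic carbon, methyl, ethyl and trifluoromethyl on this sulfur cannot be told apart in the readout. Going by these compounds alone, with trifluoromethyl held on the sulfur, the other place now gives a clean single-change reading: fluoro in place of methyl on an aromatic carbon gives a 2.1-fold higher number from compound 1 to compound 4 (0.32 log units; beyond the scatter), the only single-place step in this set that lies beyond the scatter, and a modest one. Nothing at hand bears on the reason for either finding.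

Going by these compounds, whether the flat reading on the sulfonyl sulfur extends to a longer chain, a phenyl ring or an amino group on that sulfur remains open. Also open, on these data alone, is whether the fluoro to methyl step keeps its size with methyl or ethyl on the sulfur, and how chloro or hydrogen on the same aromatic carbon would read.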